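The source may report more compounds than this note shows. Statements on the series, on what has been measured and on what is new or still open speak of the compounds shown alone.

Of the compounds shown here, three have been measured in an assay on CHO cells for displacement of a labelled ligand from 5-hydroxytryptamine receptor 1B (Homo sapiens); a higher number here means a weaker inhibitor, a lower number a stronger inhibitor. Compound 1 `c1ccc(CNCC2CCN(CCCc3c[nH]c4ccc(-n5cnnc5)cc34)CC2)cc1` gives 28 nM. Compound 2 `OC[C@H](NC1CCN(CCCc2c[nH]c3ccc(-n4ccnc4)cc23)CC1)c1ccccc1` gives 100 nM, and compound 3 `C[C@@H](NC1CCN(CCCc2c[nH]c3ccc(-n4ccnc4)cc23)CC1)c1ccccc1` gives 110 nM. On these numbers compound 2 stands second highest of the three. Its nearest neighbour is compound 3, reached by a 1.1-fold higher number from compound 2 to compound 3 (0.04 log units; within the scatter), a step within the scatter. Its furthest is compound 1, whose number is lower by an amount beyond the scatter; compound 1 also differs from compound 2 at the amine end, so its lower number cannot be assigned to the five-membered ring alone.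

Compound 4 `OC[C@H](NC1CCN(CCCc2c[nH]c3ccc(-n4cncn4)cc23)CC1)c1ccccc1` is not yet measured. It differs from compound 2 by 1H-1,2,4-triazol-1-yl in place of 1H-imidazol-1-yl on an aromatic carbon. Going by the values given here, no measured step touches this position: the single step measured, from compound 2 to compound 3, concerns the amine substituent and stays within the scatter. For the change from compound 2 to compound 4 in this assay no step beyond the scatter is therefore expected, with at most a slight lean toward a lower number because the triazolyl-bearing compound 1 gives 28 nM. Compound 4 is accordingly estimated at 80 nM, with an expected range from 30 nM to 250 nM. The step this estimate implies is expected to be a 1.3-fold lower number from compound 2 to compound 4 (0.10 log units; within the scatter).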

Compound 4, half-maximal inhibitory concentration: 400 nM
For compound 4 the middle estimate is 5.0-fold (0.70 log units) below the measured one, outside the stated range (above it).
By their numbers in this assay, from the lowest: compound 1; then compounds 2 and 3 (each within the scatter of the next); then compound 4.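

At this position on the aromatic carbon, the identity of the five-membered ring matters in this assay: 1H-1,2,4-triazol-1-yl in place of 1H-imidazol-1-yl gives a step beyond the scatter (a 4.0-fold higher number from compound 2 to compound 4 (0.60 log units; beyond the scatter)), although the ring keeps its size and its heavy-atom count, stays without net charge, and exchanges only one carbon for a nitrogen. Going by these compounds alone, this is the first reading at this place, and it contrasts with the change at the amine nitrogen, which stays within the scatter (a 1.1-fold higher number from compound 2 to compound 3 (0.04 log units; within the scatter)), so among the steps available the aromatic position is the one that moves the number. No measurement at hand accounts for the step, so it stands as an observation without an explanation.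

On these data alone, it remains open whether 1H-pyrazol-1-yl or 1H-tetrazol-1-yl at this place would continue the trend from the two rings compared here, and whether the step carries over to the 1-phenylethyl substituent of compound 3. Compound 1 differs from compound 4 in more than one place, so its value cannot settle either question.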